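Compound 2 Without Its Large Side Group

The source may hold more compounds than are shown below. What is called first, only, known or untested is meant among the compounds shown, and "the series" means these compounds.

Three related compounds have been measured so far in a physicochemical assay for solubility, read by HPLC, in phosphate buffer, measured as thermodynamic solubility, with a stated time of 24 h, at pH 7.4 (a higher number here means a more soluble compound, a lower number a less soluble compound), and their numbers lie far apart. Compound 2 (`COc1ccc(C(=O)Nc2ncc(-c3ccc(C(=O)O)cc3OCc3ccccc3OC)s2)cc1`) gives the lowest of the three at 1.4 ug/mL and sits well beyond the usual scatter of the other two. Compound 1 (`COc1ccc(C(=O)Nc2ncc(-c3ccc(C(=O)O)cn3)s2)cc1`) reaches 90 ug/mL and compound 3 (`COc1ccc(C(=O)Nc2ncc(-c3ccc(C(=O)O)nn3)s2)cc1`) reaches 1030 ug/mL in the same test.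

The next compound to consider is compound 4 (`COc1ccc(C(=O)Nc2ncc(-c3ccc(C(=O)O)cc3)s2)cc1`). It matches compound 2 except for one change, hydrogen in place of (2-methoxybenzyl)oxy on an aromatic carbon. Going by the values given here, no measured pair shows this change on its own, so any forecast is indirect. Compound 1 at 90 ug/mL and compound 3 at 1030 ug/mL both lack the (2-methoxybenzyl)oxy group and both stand far above compound 2. They also differ from compound 4 in the ring holding the carboxy group, so they guide the direction better than the size. A rise beyond the scatter is therefore expected (an 11-fold higher number from compound 2 to compound 4 (1.03 log units; beyond the scatter)). For compound 4 the estimate is 15 ug/mL and the expected range runs from 4 ug/mL to 60 ug/mL at its two ends.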

Compound 4, solubility: 2.7 ug/mL
Beside the measured number, compound 4's estimate is 5.6-fold (0.74 log units) above it; measured number below the stated range.
By their numbers in this assay, from the lowest: compounds 2 and 4 (each within the scatter of the next); then compound 1; then compound 3.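

In this assay taking the (2-methoxybenzyl)oxy group off the aromatic carbon and putting hydrogen there gives a 1.9-fold higher number from compound 2 to compound 4 (0.29 log units; within the scatter) and so leaves two compounds that this test cannot tell apart, even though the group that leaves holds 10 heavy atoms and a whole aromatic ring. The earlier compounds shown here could only hint at what this group does, since each of them also differs in the ring holding the carboxy group, whereas this pair isolates the change at this one position. Compound 4 at 2.7 ug/mL stays far under compound 1 at 90 ug/mL and compound 3 at 1030 ug/mL in the printed numbers, so among these compounds the high values go with those two rings and not with the missing side group.

Nothing available offers a reason for this result. Still open, as far as these compounds go, is whether a smaller group on this aromatic carbon, such as an amine or a short ether chain, would read the same, and whether removing the large group would matter as little on the rings of compound 1 and compound 3.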